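The compounds below may be only part of what the source reports. "The series", "measured", "known", "first", "only" and "open" are said of these compounds alone.

In a functional assay on MDA-MB-468 cells (Homo sapiens) for antiproliferative activity, read by MTT assay, with a stated time of 72 h (on this read-out lower numbers stand for stronger inhibition and higher numbers for weaker inhibition), compound 2 `COc1cc(-c2nccn2Cc2ccccc2)cc(OC)c1OC` gives only a limit of the assay, > 100000 nM. Compound 1 `CCCCn1ccnc1-c1cc(OC)c(OC)c(OC)c1` reads 44100 nM. Among the measured compounds shown here, the one measured step, an at least 2.2-fold higher number from compound 1 to compound 2 (0.35 log units; beyond the scatter), exchanges propyl for phenyl on a saturated chain carbon bound to an aromatic nitrogen, so it bears only loosely on what follows. Compound 4 `COc1ccc(-n2ccnc2-c2cc(OC)c(OC)c(OC)c2)cc1` has 4-methoxyphenyl in place of benzyl on an aromatic nitrogen. The nearest guide is compound 3 `COc1cc(OC)cc(-n2ccnc2-c2cc(OC)c(OC)c(OC)c2)c1`, which also has an aromatic ring directly on that nitrogen and reads 57500 nM. A modest move to a lower number in this assay is therefore expected, estimated as an at least 2.0-fold lower number from compound 2 to compound 4 (0.30 log units; that floor lies within the scatter). For compound 4 the expected value is 50000 nM, with an estimated range of 18000 nM to 100000 nM.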

Compound 4, half-maximal inhibitory concentration: 500 nM
Beside the measured number, compound 4's estimate is 100-fold (2.00 log units) above it; measured number below the stated range.
By their numbers in this assay, from the lowest: compound 4; then compounds 1 and 3 (each within the scatter of the next). At a limit, above all of these: compound 2.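

The change on this aromatic nitrogen is large (an at least 200-fold lower number from compound 2 to compound 4 (2.30 log units; beyond the scatter)), and replacing butyl gives a similar result (an 88-fold lower number from compound 1 to compound 4 (1.95 log units; beyond the scatter)). An aromatic ring directly on that nitrogen is not enough in itself: compound 3 also has one and reads 57500 nM as against compound 4 at 500 nM, so the substitution on that ring matters. Compound 2 stands at a limit, so its step gives only a floor: the limit of > 100000 nM in this assay, at which 1 of the 4 values shown sits.

On these data alone, it remains open whether an amine or a hydroxyl in place of the methoxy of the 4-methoxyphenyl keeps the activity of compound 4.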